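Methoxy Ester in Place of an Aryl Ketone

The source may hold more compounds than are shown below. What is called first, only, known or untested is meant among the compounds shown, and "the series" means these compounds.

Compound 1 `O=C(NNC(=O)c1ccncc1)C(=O)Nc1cc(Cl)ccc1O`: 1200000 nM
Compound 2 `Cc1ccccc1C(=O)/C=C1\Nc2ccccc2OC1=O`: > 1790000 nM
Compound 3 `O=C(NNC(=O)c1ccncc1)C(=O)Nc1ccccc1O`: 1410000 nM

Of the compounds shown here, three have been measured in an ADME assay on Vero cells (Chlorocebus sabaeus) for cytotoxicity, read by MTT assay, with a stated time of 72 h; a lower number here means that less compound is tolerated, a higher number that more compound is tolerated. Among the measured compounds shown here, compound 1 and compound 3 gave numbers, and the one step between them, a 1.2-fold higher number from compound 1 to compound 3 (0.07 log units; within the scatter), lies within the scatter. Compound 2 stands apart: for it this assay reports only a limit, (the limit of > 1790000 nM in this assay, at which 1 of the 3 values shown sits).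

Compound 4 `COC(=O)/C=C1\Nc2ccccc2OC1=O` has not been measured. It differs from compound 2 by methoxy in place of 2-methylphenyl on a carbonyl carbon. For the measured compounds named here, the single measured step concerns hydrogen in place of chloro on another pair and does not bear on a change at a carbonyl carbon, so no measured step guides this one. No shift beyond the scatter is therefore expected in this assay, and compound 4 may again sit at the limit. Compound 4 is expected to give 1800000 nM, between 900000 nM and 3600000 nM. The step this estimate implies is a step that the limit leaves unreadable from compound 2 to compound 4.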

Compound 4, half-maximal cytotoxic concentration: > 2280000 nM
Compound 4: only a limit was reported; the forecaster's own chance of this, stated with the estimate: 70%; middle value at least 1.2-fold (0.10 log units) from the limit.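

Compound 2 and compound 4 each carry only a limit in this assay, and the step between them cannot be read. The compounds shown leave open whether methoxy in place of 2-methylphenyl on a carbonyl carbon shifts this read-out at all.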